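Swapping the Enone Direction on a Fused Core

This account rests on a few compounds, and the source may have more. Where it says the series, first, only, none or still open, it means among the compounds named here.

Measured compounds:
compound 1 `COc1ccc(-c2cc(/C=C/C(=O)c3cc(OC)c(OC)c(OC)c3)nc3cc(-c4ccccc4)nn23)cc1OC`: 7200 nM
compound 2 `COc1ccc(-c2cc(C(=O)/C=C/c3ccc(C)cc3)nc3cc(-c4ccccc4)nn23)cc1OC`: 22200 nM

In a functional assay on A549 cells (Homo sapiens) for antiproliferative activity, read by MTT assay, with a stated time of 24 h (on this read-out higher numbers stand for weaker inhibition and lower numbers for stronger inhibition), compound 2 gives 22200 nM, the higher of the two numbers; compound 1 gives 7200 nM, a difference beyond the scatter. Compound 3 `COc1ccc(-c2cc(/C=C/C(=O)c3ccc(C)cc3)nc3cc(-c4ccccc4)nn23)cc1OC` differs from compound 2 only by 2-((4-methylphenyl)carbonyl)ethenyl in place of (2-(4-methylphenyl)ethenyl)carbonyl on an aromatic carbon. Among the compounds with values here, compound 1 differs from compound 3 in more than one place, so no step between them is known. Within the data shown here, with no measured step of this kind, a modest move toward lower numbers is expected, near the scatter. Compound 3 is expected to give 13000 nM, between 4500 nM and 38000 nM. The expected step is a 1.7-fold lower number from compound 2 to compound 3 (0.23 log units; within the scatter).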

Compound 3, half-maximal inhibitory concentration: 17200 nM
The estimate for compound 3 lay 1.3-fold (0.12 log units) below the measured number; measured number inside the range.
By their numbers in this assay, from the lowest: compound 1; then compounds 3 and 2 (each within the scatter of the next).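

Turning the linker around, with 2-((4-methylphenyl)carbonyl)ethenyl in place of (2-(4-methylphenyl)ethenyl)carbonyl, gives a 1.3-fold lower number from compound 2 to compound 3 (0.11 log units; within the scatter) in this assay, so the two directions cannot be told apart here. With the direction held fixed, the ring on the carbonyl carbon does count: 4-methylphenyl in place of 3,4,5-trimethoxyphenyl gives a 2.4-fold higher number from compound 1 to compound 3 (0.38 log units; beyond the scatter) as a modest step. Nothing measured here accounts for either result.

Still open, as far as these compounds go, is whether direction matters as little with 3,4,5-trimethoxyphenyl on the linker, and how an amine or a carboxylic acid on that ring would read.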